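The source may report more compounds than this note shows. Statements on the series, on what has been measured and on what is new or still open speak of the compounds shown alone.

Of the compounds shown here, three sharing one core have been measured in a functional assay on HepG2 cells (Homo sapiens) for inhibition, read by MTT assay, with a stated time of 48 h; on this read-out higher numbers stand for weaker inhibition and lower numbers for stronger inhibition: compound 1 (`COc1ccc(N(C)c2nc(C)nc3ccccc23)cc1OCCC[Se]C#N`) gives 1040 nM, compound 2 (`COc1ccc(N(C)c2nc(C)nc3ccccc23)cc1C(=O)OCCC[Se]C#N`) gives 340 nM, and compound 3 (`COc1ccc(N(C)c2nc(C)nc3ccccc23)cc1OCCCC[Se]C#N`) gives 6460 nM. Compound 3 therefore carries the highest number of the three and is the weakest inhibitor in this small set. The gaps to it are a 6.2-fold higher number from compound 1 to compound 3 (0.79 log units; beyond the scatter) and a 19-fold higher number from compound 2 to compound 3 (1.28 log units; beyond the scatter), both beyond the scatter.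

Compound 4 (`COc1ccc(N(C)c2nc(C)nc3ccccc23)cc1OCCN`) differs from compound 3 by one nitrogen atom in place of a group of 5 heavy atoms (3 carbon, 1 nitrogen, 1 selenium; no ring), on a saturated chain carbon, two bonds along the chain from an oxygen on an aromatic ring. The selenium-bearing group is lost and an amino group enters. Within the data shown here, no measured step removes the selenium, so the data offer no direct precedent for this change. The closest guide is a 6.2-fold higher number from compound 1 to compound 3 (0.79 log units; beyond the scatter), a change in chain length alone, while a 3.1-fold lower number from compound 1 to compound 2 (0.49 log units; beyond the scatter) shows a further shift with a change in the link to the aromatic ring. Both measured neighbours of compound 3 lie lower, so a modest move towards lower numbers seems more likely than a further rise, though with little certainty.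

The expected step is a 3.2-fold lower number from compound 3 to compound 4 (0.51 log units; beyond the scatter), a modest one in that direction. In this assay, compound 4 is estimated at 2000 nM, with an expected range from 300 nM to 12000 nM.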

Compound 4, half-maximal inhibitory concentration: 343 nM
Estimate against measurement, compound 4: 5.8-fold (0.77 log units) above, within the range that was stated.
By their numbers in this assay, from the lowest: compounds 2 and 4 (each within the scatter of the next); then compound 1; then compound 3.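

In this assay the result shows that the selenium-bearing group is not needed for inhibition at this level in these compounds: with the amino group on a saturated chain carbon, two bonds along the chain from an oxygen on an aromatic ring, the shortened chain gives a 19-fold lower number from compound 3 to compound 4 (1.27 log units; beyond the scatter) and a 3.0-fold lower number from compound 1 to compound 4 (0.48 log units; beyond the scatter). Compound 4, which has no selenium, also cannot be told apart from the carbonyl-linked selenium compound, as the step shows a 1.0-fold higher number from compound 2 to compound 4 (0.00 log units; within the scatter), so two quite different groups on the shared core reach the same region of the read-out. No measured information on the compounds explains why the amino group does so well at this place.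

The compounds shown cannot separate what the amino group itself contributes from what follows from losing the selenium-bearing group, and a hydroxyl group or a dimethylamino group at the same chain end would help to tell these apart. On these data alone, it also remains open how the amine responds to chain length, which a longer chain ending in the same amino group would test, and whether a carboxylic acid at this place would keep the number as low.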